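The compounds below may be only part of what the source reports. "The series", "measured", "known", "first", "only" and "open" are said of these compounds alone.

In an ADME assay on Vero cells (Chlorocebus sabaeus) for cytotoxicity, read by fluorescence and resazurin assay, with a stated time of 3 days (a lower number here means that less compound is tolerated, a higher number that more compound is tolerated), compound 2 `CCOC(=O)C[C@@H]([C@H]1O[C@@H]2OC(C)(C)O[C@@H]2[C@H]1OCc1ccccc1)n1cnc2c(NCc3ccccc3)ncnc21` gives 57500 nM and compound 1 `CC1(C)O[C@H]2O[C@H]([C@H](CCO)n3cnc4c(N)ncnc43)[C@H](OCc3ccccc3)[C@H]2O1` gives 97100 nM. These two numbers lie within the usual scatter of each other, so neither compound stands apart. Compound 3 `CC1(C)O[C@H]2O[C@H]([C@H](CCO)n3cnc4c(NCc5ccccc5)ncnc43)[C@H](OCc3ccccc3)[C@H]2O1` is compound 2 with hydroxymethyl in place of ethoxycarbonyl on a saturated chain carbon, two bonds along the chain from an aromatic nitrogen and a saturated ring carbon. Read one bond further out, (ethoxycarbonyl)methyl becomes 2-hydroxyethyl, the chain that compound 1 also carries. Within the data shown here, no measured pair differs in only one place, so the data offer no direct guide to this change. With both measured values so close, no step beyond the scatter is expected in this assay. The estimated change is small, a 1.2-fold higher number from compound 2 to compound 3 (0.09 log units; within the scatter). For compound 3 the expected value is 70000 nM, with an estimated range of 30000 nM to 160000 nM.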

Compound 3, half-maximal cytotoxic concentration: 61200 nM
For compound 3 the middle estimate is 1.1-fold (0.06 log units) above the measured one; measured number inside the range.
By their numbers in this assay, from the lowest: compounds 2, 3 and 1 (each within the scatter of the next).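

In this assay, the exchange of ethoxycarbonyl for hydroxymethyl on a saturated chain carbon, two bonds along the chain from an aromatic nitrogen and a saturated ring carbon, can now be read directly, as a 1.1-fold higher number from compound 2 to compound 3 (0.03 log units; within the scatter), so the two groups cannot be told apart at this place. Among these compounds, the new compound also gives the first direct reading of benzyl in place of hydrogen on a nitrogen on an aromatic ring, as a 1.6-fold lower number from compound 1 to compound 3 (0.20 log units; within the scatter), and this step also lies within the scatter. There is no supporting information that would explain either result.

As far as these compounds go, it remains open whether a carboxylic acid or an amine at the end of this chain would give a number that stands apart from these. The same question applies to a longer chain in place of benzyl on that nitrogen.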